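Aryl exchange at the shared core: channel inhibition notes

The source may hold more compounds than are shown below. What is called first, only, known or untested is meant among the compounds shown, and "the series" means these compounds.

Measured so far:
compound 1: `C[C@H](NC(=O)c1cc(C(F)(F)F)nn1C)c1nc(-c2ccncc2)no1` — 5250 nM
compound 2: `C[C@H](NC(=O)c1cc(C(F)(F)F)nn1C)c1nc(-c2cnn(C)c2)no1` — 2640 nM

In an assay on T-REx-293 cells for inhibition of potassium channel subfamily T member 1 (Homo sapiens), read by patch clamp (on this read-out lower numbers stand for stronger inhibition and higher numbers for weaker inhibition), compound 1 gives 5250 nM. In this assay compound 2 gives 2640 nM, the lowest of the two numbers shown, with compound 1 nearest; the step of a 2.0-fold lower number from compound 1 to compound 2 (0.30 log units; within the scatter) lies within the scatter, so no order of the two is claimed.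

Compound 3 `CNc1cc(-c2noc([C@H](C)NC(=O)c3cc(C(F)(F)F)nn3C)n2)ccn1` is the next member. Its change from compound 2 is 2-(methylamino)pyridin-4-yl in place of 1-methyl-1H-pyrazol-4-yl on an aromatic carbon. Among the measured compounds shown here, only one measured step exists, a 2.0-fold lower number from compound 1 to compound 2 (0.30 log units; within the scatter), and it concerns the exchange of pyridin-4-yl for 1-methyl-1H-pyrazol-4-yl at the same position; no measured step covers a methylamino group entering a pyridinyl ring. The re-entry of a pyridin-4-yl-type group, with that single step within the scatter, gives no ground to expect a move beyond the scatter in this assay: the expected step is a 1.2-fold higher number from compound 2 to compound 3 (0.08 log units; within the scatter).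

For compound 3 in this assay the estimate is 3200 nM, expected within 1000 nM to 10000 nM.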

Compound 3, half-maximal inhibitory concentration: 195 nM
Beside the measured number, compound 3's estimate is 16-fold (1.22 log units) above it; the whole stated range lies above it.
By their numbers in this assay, from the lowest: compound 3; then compounds 2 and 1 (each within the scatter of the next).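

In this assay, the aryl group on the aromatic carbon between two ring nitrogen atoms proves able to move the number well beyond the scatter, with a 14-fold lower number from compound 2 to compound 3 (1.13 log units; beyond the scatter), whereas the earlier exchange at this position, a 2.0-fold lower number from compound 1 to compound 2 (0.30 log units; within the scatter), did not. The single-place comparison with pyridin-4-yl gives a 27-fold lower number from compound 1 to compound 3 (1.43 log units; beyond the scatter), so within this pair the large step goes with methylamino in place of hydrogen on an aromatic carbon, not with the pyridin-4-yl group itself. No measurement shown here bears on why this step is so large.

As far as these compounds go, it remains open whether an unsubstituted amino group, a dimethylamino group or a methoxy group in place of methylamino on the pyridin-4-yl ring would keep this step. Also open, from the compounds shown here alone, is whether methylamino gives a step of similar size at another carbon of that ring.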